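A few compounds are considered here, and "the series" means these few. Any claim that something is new, unique, unknown or untested is made for them only; others in the source may bear on it.

Compound 1 `O=C1C=C(N2CCC2)C(=O)c2c1nc1n2[C@H]2OC[C@@H](O)[C@H]2OC1`: > 16000 nM
Compound 2 `O=C1C(N2CCCCC2)=CC(=O)c2c1nc1n2[C@H]2OC[C@@H](O)[C@H]2OC1`: > 8000 nM
Compound 3 `O=C1C(N2CCC2)=CC(=O)c2c1nc1n2[C@H]2OC[C@@H](O)[C@H]2OC1`: > 16000 nM

In a functional assay on ECa-109 cells for inhibition, with ECa-109 cell line (Homo sapiens) as the target, read by sulforhodamine B assay (on this read-out higher numbers stand for weaker inhibition and lower numbers for stronger inhibition), compound 1 gives > 16000 nM, which is a limit of the assay and not a number. In this assay compound 2 gives > 8000 nM, also a limit. In this assay compound 3 gives > 16000 nM, again a limit. Compound 1 therefore stands at a limit rather than at a measured number, and the two other values shown are limits as well: the limit of > 16000 nM in this assay, at which 2 of the 3 values shown sit, and (the limit of > 8000 nM in this assay, at which 1 of the 3 values shown sits). Within the data shown here, the only one-place step among the measured compounds, a step that the two limits leave unreadable from compound 2 to compound 3, has no readable size, since each of its ends is a limit.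

Compound 4 `Cc1ccc(NC2=CC(=O)c3nc4n(c3C2=O)[C@H]2OC[C@@H](O)[C@H]2OC4)cc1` differs from compound 1 in one place: (4-methylphenyl)amino in place of azetidin-1-yl on a double-bonded ring carbon. Among the measured compounds shown here, none of the measured steps bears on this change, and the one step recorded gives no size, so no direction can be drawn from the measured compounds. On that footing compound 4 is expected to sit near the region where the measured compounds sit, with an estimate of 8000 nM and a range from 1000 nM to 40000 nM. This amounts to an expected step of an at least 2.0-fold lower number from compound 1 to compound 4 (0.30 log units; that floor lies within the scatter).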

Compound 4, half-maximal inhibitory concentration: 3480 nM
Compound 4: the middle estimate sits 2.3-fold (0.36 log units) above what was measured; the measured number falls inside the stated range.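

Placing (4-methylphenyl)amino instead of azetidin-1-yl on this double-bonded ring carbon gives the first readable step at this position: in this assay there is an at least 4.5-fold lower number from compound 1 to compound 4 (0.66 log units; beyond the scatter). Compound 1 holds a limit and not a number, so that size is only a floor and the true step may be larger: the limit of > 16000 nM in this assay, at which 2 of the 4 values shown sit. The change replaces a four-membered non-aromatic ring with a six-membered aromatic ring of carbon only and also adds a hydrogen-bond donor, and since these arrive together, this one step cannot separate them.

Still open, going by these compounds, is which part of the new group matters, a question that phenylamino without the methyl, or an open-chain group such as butylamino, would begin to answer. Also open, on these data alone, is whether (4-methylphenyl)amino would give a number on the ring carbon that holds piperidin-1-yl in compound 2, since the step between compound 2 and compound 3 cannot be read, both of its ends being limits.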